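The source may report more compounds than this note shows. Statements on the series, on what has been measured and on what is new or still open speak of the compounds shown alone.

Measured in an in vitro functional assay on HEK285-7 cells for antagonist activity at prostaglandin D2 receptor 2 (Homo sapiens), read by BRET and beta-arrestin recruitment; on this read-out lower numbers stand for smaller maximal responses and higher numbers for larger maximal responses:
Compound 1 `COc1cc(-c2nc(C(c3ccc(F)cc3)c3ccc(F)cc3)sc2CC(=O)O)ccn1` gives 60%.
Compound 2 `O=C(O)Cc1sc(NCc2ccccc2)nc1-c1ccc(Cl)cc1` gives 30%.
Compound 3 `COc1ccc(C(c2ccccn2)c2nc(-c3ccc(Cl)cc3)c(CC(=O)O)s2)cc1` gives 80%.

Among these three values compound 1 stands second highest. Compound 3 is its nearest neighbour and lies above it, beyond the scatter; compound 2 lies furthest from it, below it, also beyond the scatter. Compound 4 `O=C(O)Cc1sc(C(c2ccc(F)cc2)c2ccc(F)cc2)nc1-c1ccoc1` has not yet been measured in this assay. It differs from compound 1 in one place: furan-3-yl in place of 2-methoxypyridin-4-yl on an aromatic carbon. Among the measured compounds shown here, no measured pair shows this change, and compounds 2 and 3 both differ from compound 1 in more than one place, giving no precedent. A modest drop, a number 10 percentage points lower from compound 1 to compound 4 (within the scatter), is expected, though a shift within the scatter is just as plausible. Compound 4 is estimated at 50%, with a range from 25% to 80%.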

Compound 4, largest response reached (reported as efficacy), in percent of the reference or control that the assay uses: 80%
Beside the measured number, compound 4's estimate is 30 percentage points below it; the measured number falls inside the stated range.
By their numbers in this assay, from the lowest: compound 2; then compound 1; then compounds 3 and 4 (each within the scatter of the next).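

In this assay, placing furan-3-yl instead of 2-methoxypyridin-4-yl on the aromatic carbon next to the ring nitrogen gives a number 20 percentage points higher from compound 1 to compound 4 (beyond the scatter) with the rest of the molecule unchanged. This first single-place comparison shows that the maximal response depends on the group held at this position. No measurement at hand explains the step.

The compounds shown leave open whether the step follows the change in ring size, the ring hetero atom or the loss of the methoxy group. Pyridin-4-yl or thiophen-3-yl at this position would help separate these.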